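Swapping the aryl group of compound 2 for pyridin-3-yl

The source may report more compounds than this note shows. Statements on the series, on what has been measured and on what is new or still open speak of the compounds shown alone.

The measured compounds and their numbers:
compound 1, `N#Cc1ccc(-c2cnc3[nH]cc(-c4nnc(-c5ccc(F)cc5)o4)c(=O)c3c2)cc1`, 12.6%
compound 2, `CS(=O)(=O)c1ccc(-c2cnc3[nH]cc(-c4nnc(-c5ccc(F)cc5)o4)c(=O)c3c2)cc1`, 14.9%
compound 3, `CS(=O)(=O)c1ccc(-c2cnc3[nH]cc(-c4nnc(-c5ccccc5)o4)c(=O)c3c2)cc1`, 8.6%

All three were tested in a functional assay on HCT-116 cells (Homo sapiens) for inhibition, read by MTT assay, with a stated time of 24 h, tested at 5 uM; on this read-out lower numbers stand for less inhibition of growth and higher numbers for more inhibition of growth at the one concentration tested. The three numbers lie close together: the step of a number 2.3 percentage points higher from compound 1 to compound 2 (within the scatter) and the step of a number 6.3 percentage points lower from compound 2 to compound 3 (within the scatter) are both within the scatter, so compound 2 cannot be told apart from compound 1 or compound 3 on these numbers, and all three show little inhibition of growth.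

Compound 4, `O=c1c(-c2nnc(-c3ccc(F)cc3)o2)c[nH]c2ncc(-c3cccnc3)cc12`, has not yet been measured. It differs from compound 2 in one place: pyridin-3-yl in place of 4-(methylsulfonyl)phenyl on an aromatic carbon. For the measured compounds named here, of the measured steps, only the step from compound 1 to compound 2 touches the same position, where one substituent on the phenyl ring was exchanged for another; that step was a number 2.3 percentage points higher from compound 1 to compound 2 (within the scatter). The step from compound 2 to compound 3 concerns the fluoro on the other ring and so says little here. Going by the values given here, no measured step replaces the whole ring, so the change to compound 4 reaches beyond what the data cover.

Given that every exchange so far stayed within the scatter, a step of a number 3.9 percentage points lower from compound 2 to compound 4 (within the scatter) is expected, with no direction beyond the scatter. Compound 4 is therefore estimated at 11%, with a range from 2% to 22%.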

Compound 4, percent growth inhibition at one concentration: 11.1%
The estimate for compound 4 lay 0.1 percentage points below the measured number, within the range that was stated.
By their numbers in this assay, from the lowest: compounds 3, 4, 1 and 2 (each within the scatter of the next).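

In this assay, the exchange of the whole ring at this position comes to a number 3.8 percentage points lower from compound 2 to compound 4 (within the scatter), and the same exchange starting from the nitrile-bearing ring comes to a number 1.5 percentage points lower from compound 1 to compound 4 (within the scatter). The earlier compounds shown here only swapped one substituent on a phenyl ring, whereas compound 4 has neither the methylsulfonyl nor the cyano group, carries a ring with a nitrogen in it, and is built from a smaller group, yet it cannot be told apart from compound 1 or compound 2, so at this position none of these three aryl groups stands out and inhibition of growth stays small. Nothing measured here bears on the reason for this flat result.

All the groups shown at this position are six-membered aromatic rings, so it remains open whether something of a different kind, such as a piperazine ring with its amine, a phenyl ring carrying a carboxylic acid, or a longer alkyl chain, would move the number beyond the scatter. From the compounds shown here alone, it is also open whether moving the ring nitrogen, as in pyridin-4-yl, would make any difference.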